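Dimethylamino in Place of Methoxy: What to Expect for Compound 4

A few compounds are considered here, and "the series" means these few. Any claim that something is new, unique, unknown or untested is made for them only; others in the source may bear on it.

The measured compounds and their values in a functional assay for inhibition, with Homo sapiens as the target; a higher number here means a weaker inhibitor, a lower number a stronger inhibitor:
Compound 1 `CC1CCN(c2ccc(Nc3nccc(-c4cccnc4)n3)cc2)CC1` gives 500 nM.
Compound 2 `NS(=O)(=O)c1ccc(Nc2nccc(-c3cccnc3)n2)cc1` gives 200 nM.
Compound 3 `COc1ccc(Nc2nccc(-c3cccnc3)n2)cc1` gives 1700 nM.

Compound 3 stands at the highest number of the three, and therefore as the weakest inhibitor among them; its nearest neighbour is compound 1, with a 3.4-fold higher number from compound 1 to compound 3 (0.53 log units; beyond the scatter), and the furthest is compound 2, with an 8.5-fold higher number from compound 2 to compound 3 (0.93 log units; beyond the scatter). Both steps that reach compound 3 are beyond the scatter and both lie in the same direction: replacing either the 4-methylpiperidin-1-yl group or the sulfamoyl group with methoxy raised the number.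

Compound 4 `CN(C)c1ccc(Nc2nccc(-c3cccnc3)n2)cc1` differs from compound 3 in one place: dimethylamino in place of methoxy on an aromatic carbon. Of the measured steps, the one that bears most on this change is the move from compound 1 to compound 3, since dimethylamino, like 4-methylpiperidin-1-yl, is a group that carries its one nitrogen directly on the aromatic carbon. That step was modest and beyond the scatter. Reversing the direction, the account expects compound 4 to lie at a lower number than compound 3, by a step of roughly a 2.8-fold lower number from compound 3 to compound 4 (0.45 log units; beyond the scatter), because compound 1 gave 500 nM. Compound 4 is therefore estimated at 600 nM, within a range of 250 nM to 1500 nM.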

Compound 4, half-maximal inhibitory concentration: 2800 nM
For compound 4 the middle estimate is 4.7-fold (0.67 log units) below the measured one, outside the stated range (above it).
By their numbers in this assay, from the lowest: compound 2; then compound 1; then compounds 3 and 4 (each within the scatter of the next).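

In this assay, dimethylamino and methoxy on this aromatic carbon, para to a large group, cannot be told apart (a 1.6-fold higher number from compound 3 to compound 4 (0.22 log units; within the scatter)), so on the evidence of this pair, exchanging the oxygen-linked group for the nitrogen-linked one does not shift the number. A nitrogen on the aromatic carbon is also not enough to reproduce the value of compound 1: dimethylamino and 4-methylpiperidin-1-yl both carry one there, yet the step between them lies beyond the scatter (a 5.6-fold higher number from compound 1 to compound 4 (0.75 log units; beyond the scatter)). Sulfamoyl now stands further still from dimethylamino, in a large step (a 14-fold higher number from compound 2 to compound 4 (1.15 log units; beyond the scatter)), and compound 2 keeps the lowest number of the four, with steps beyond the scatter to each of the others.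

Why the ring of 4-methylpiperidin-1-yl and the sulfamoyl group each give a lower number than dimethylamino stays open, as nothing here gives a reason for any of these steps. As far as these compounds go, it also remains open where a primary amine, a morpholine ring, a carboxylic acid or a longer chain on the nitrogen would fall on this carbon, and whether a sulfonamide with methyl groups on its nitrogen would keep the number of compound 2.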